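Chloro in place of hydrogen: working notes

The source may hold more compounds than are shown below. What is called first, only, known or untested is meant among the compounds shown, and "the series" means these compounds.

Measured so far in a physicochemical assay for acid dissociation:
- compound 1 `CC1(C)CCc2cc(O)ccc2O1`: 10.3
- compound 2 `CC1(C)CCc2cc(O)c(Cl)cc2O1`: 9.1

Of the two measured compounds, compound 1 stands highest at 10.3 and compound 2 is its nearest neighbour. Compound 3 `CC1(C)CCc2cc(O)cc(Cl)c2O1` has not yet been measured. It differs from compound 1 by chloro in place of hydrogen on an aromatic carbon, with the chloro meta to a hydroxy group, ortho to a fused ring and meta to a fused ring.

Going by the values given here, one measured step bears on this change, and it is also a chloro in place of hydrogen on an aromatic carbon. That step is a number 1.20 log units lower from compound 1 to compound 2 (beyond the scatter) and it is large. The chloro of compound 3 sits on a different aromatic carbon, however, and no measurement exists for a chloro at that place. The step to compound 2 is therefore only a rough guide. A step in the same direction is expected, somewhat smaller but still beyond the scatter.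

The estimated step is a number 0.80 log units lower from compound 1 to compound 3 (beyond the scatter) in this assay. For compound 3 the expected value is 9.5, with an estimated range from 9.1 to 9.9.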

Compound 3, acid dissociation constant: 9.8
Compound 3: the middle estimate sits 0.30 log units below what was measured, and the stated range covers the measured number.
By their numbers in this assay, from the lowest: compound 2; then compound 3; then compound 1.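

In this assay, a chloro on this aromatic carbon, meta to a hydroxy group, ortho to a fused ring and meta to a fused ring, gives a number 0.50 log units lower from compound 1 to compound 3 (beyond the scatter) in a modest step. The change in direction is therefore not confined to the carbon that bears the chloro in compound 2, but its size depends on the place, since the other chloro step is large, at a number 1.20 log units lower from compound 1 to compound 2 (beyond the scatter) on the same scale. Nothing in the data accounts for this difference in size between the two carbons.

The compounds shown leave open whether a fluoro, a methoxy or a nitrile in place of hydrogen on this same carbon would give a step in the same direction and of similar size, so the step cannot yet be assigned to chloro in particular rather than to substitution at this place. They also leave open how the number in this assay behaves when chloro stands on both carbons of the core at once, and whether the two single steps would then simply add.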